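The source may hold more compounds than are shown below. What is called first, only, known or untested is meant among the compounds shown, and "the series" means these compounds.

Compound 1, `COc1cc(-c2cc(/C=C/C(=O)c3ccc(N)cc3)[nH]n2)cc(OC)c1OC`: 7530 nM
Compound 2, `COc1ccc(C(=O)/C=C/c2cc(-c3cc(OC)c(OC)c(OC)c3)n[nH]2)cc1`: 19600 nM
Compound 3, `COc1cc(-c2cc(/C=C/C(=O)c3ccc(F)c(F)c3)[nH]n2)cc(OC)c1OC`: 5890 nM

All three measured compounds share one core and differ only in the aryl group on the carbonyl carbon. In a functional assay on SK-MEL-2 cells (Homo sapiens) for inhibition, read by sulforhodamine B assay, with a stated time of 48 h (on this read-out lower numbers stand for stronger inhibition of growth and higher numbers for weaker inhibition of growth), compound 1 gives 7530 nM, the second highest of the three numbers. Its nearest neighbour is compound 3, with a 1.3-fold lower number from compound 1 to compound 3 (0.11 log units; within the scatter); compound 2 stands furthest, with a 2.6-fold higher number from compound 1 to compound 2 (0.42 log units; beyond the scatter). The remaining pair shows a 3.3-fold lower number from compound 2 to compound 3 (0.52 log units; beyond the scatter).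

Compound 4, `COc1ccc(-c2cc(/C=C/C(=O)c3ccc(N)cc3)[nH]n2)cc1OC`, is not yet measured. It differs from compound 1 in one place: hydrogen in place of methoxy on an aromatic carbon. Among the compounds with values here, this change sits on the aryl attached to the core, not on the aryl attached to the carbonyl carbon, and none of the measured steps touches that ring; all three alter the carbonyl-side aryl, where two steps went beyond the scatter and one stayed within it. Within the data shown here, for trimming one methoxy on the other ring there is no precedent among the measured compounds, so the expectation rests on compound 1 alone and carries a wide range. The expected step from compound 1 is a 1.3-fold higher number from compound 1 to compound 4 (0.10 log units; within the scatter), which is not expected to go beyond the scatter in either direction. Compound 4 is estimated at 9500 nM in this assay, with a range from 4000 nM to 24000 nM.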

Compound 4, concentration for total growth inhibition: 22200 nM
Beside the measured number, compound 4's estimate is 2.3-fold (0.37 log units) below it; measured number inside the range.
By their numbers in this assay, from the lowest: compounds 3 and 1 (each within the scatter of the next); then compounds 2 and 4 (each within the scatter of the next).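

Within the data shown here, the ring on the core, which none of the earlier steps touched, is not a silent part of the series: in this assay, hydrogen in place of methoxy on an aromatic carbon, ortho to a methoxy group and meta to a methoxy group, gives a 2.9-fold higher number from compound 1 to compound 4 (0.47 log units; beyond the scatter), a step beyond the scatter. This single methoxy therefore counts on its own, and a change on this ring can weigh as much in this read-out as the modest change on the carbonyl-side aryl seen in a 2.6-fold higher number from compound 1 to compound 2 (0.42 log units; beyond the scatter), so the carbonyl-side aryl is not the only place in the series that moves the number. Nothing among the data shown accounts for the step, which stands here as an observation from one matched pair.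

As far as these compounds go, whether the same change gives a step of similar size with 3,4-difluorophenyl or 4-methoxyphenyl on the carbonyl carbon stays open, since the step is known only with 4-aminophenyl there. Also open, from the compounds shown here alone, is whether the methoxy itself matters or only the presence of some group at this place, which a hydroxyl, an ethoxy or a chlorine atom there would help to separate.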